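Clearance notes on the step to compound 3

The source may report more compounds than this note shows. Statements on the series, on what has been measured and on what is new or still open speak of the compounds shown alone.

In an in vitro ADME assay on microsomes from liver (Homo sapiens) for metabolic stability (on this read-out lower numbers stand for slow clearance and higher numbers for fast clearance), compound 1 `Cc1oc(-c2ccccc2)nc1CN1C[C@H](C(=O)NCc2cccc(N)n2)C[C@@H](c2ccccc2)C1` is reported only as a limit, > 300 mL.min-1.g-1. Within the data shown here, compound 2 `Cc1cccc(CNC(=O)C2CCCN(Cc3nc(-c4ccccc4)oc3C)C2)n1` gives 158 mL.min-1.g-1, the only actual number available so far. Among the measured compounds shown here, compound 2 therefore has no measured neighbour differing in one place, and no measured step is available as a guide.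

Compound 3 `Cc1oc(-c2ccccc2)nc1CN1CCCC(C(=O)NCC2CCOCC2)C1` keeps the rest of compound 2 and carries one change: oxan-4-yl in place of 6-methylpyridin-2-yl on a saturated chain carbon bound to an amide-type nitrogen. In words, oxan-4-yl stands in place of 6-methylpyridin-2-yl on a saturated chain carbon bound to an amide-type nitrogen.

The expectation rests only on this structural change and on the value of compound 2, 158 mL.min-1.g-1. A modest move towards slower clearance is expected, only slightly beyond the usual scatter, and with low confidence given the lack of any measured step. The estimated change is a 2.3-fold lower number from compound 2 to compound 3 (0.35 log units; beyond the scatter). For compound 3 the expected clearance in this assay is 70 mL.min-1.g-1, with an estimated range of 25 mL.min-1.g-1 to 180 mL.min-1.g-1.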

Compound 3, intrinsic clearance in microsomes: 105 mL.min-1.g-1
For compound 3 the middle estimate is 1.5-fold (0.18 log units) below the measured one; low and high end bracket the measured number.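

Among these compounds, this is the only step that can be read in this assay: oxan-4-yl in place of 6-methylpyridin-2-yl on a saturated chain carbon bound to an amide-type nitrogen gives a 1.5-fold lower number from compound 2 to compound 3 (0.18 log units; within the scatter). At this place, then, a six-membered aromatic ring with 1 hetero atom and a six-membered non-aromatic ring with 1 hetero atom cannot be told apart on this read-out, and the exchange of one ring type for the other leaves compound 3 within the scatter of compound 2. Nothing in the data shown gives a cause for this result, or bears on the step.

As far as these compounds go, a single step within the scatter says little about the place as a whole, so it remains open whether the same holds for groups of another kind there, such as a carboxylic acid, an amine or a longer chain carrying the oxan-4-yl ring. Among the compounds shown here, it also remains open whether oxan-4-yl would behave in the same way on a core other than that of compound 2, since no second pair with this change is available.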